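From 4-propylphenyl to 2-ethoxyphenyl at the limit

This account rests on a few compounds, and the source may have more. Where it says the series, first, only, none or still open, it means among the compounds named here.

Compound 1 (`O=C1C(Nc2ccccc2)=CC(=O)c2c1nc1n2[C@H]2OC[C@@H](O)[C@H]2OC1`) gives only the limit > 4000 nM in a functional assay on MCF7 cells (Homo sapiens) for inhibition, read by sulforhodamine B assay (on this read-out lower numbers stand for stronger inhibition and higher numbers for weaker inhibition), and no number. Compound 2 (`CCCc1ccc(NC2=CC(=O)c3c(nc4n3[C@H]3OC[C@@H](O)[C@H]3OC4)C2=O)cc1`) also gives only the limit > 4000 nM and no number. Compound 3 (`CCOc1ccccc1NC1=CC(=O)c2c(nc3n2[C@H]2OC[C@@H](O)[C@H]2OC3)C1=O`) carries 2-ethoxyphenyl in place of 4-propylphenyl on an amine nitrogen. Among the compounds with values here, the one measured change, a step that the two limits leave unreadable from compound 1 to compound 2 here, offers no size to carry over, and the sole guide is the limit of > 4000 nM in this assay, at which 2 of the 2 values shown sit. The estimated change is therefore a number no higher from compound 2 to compound 3 (the limit leaves the size open) in this assay and none beyond the scatter is expected. Compound 3 is expected at 4000 nM (estimated range 1500 nM to 8000 nM).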

Compound 3, half-maximal inhibitory concentration: > 4000 nM
Compound 3 ended at the assay's limit; the forecaster's own chance of this, stated with the estimate: 70%; the middle value sits exactly at the limit.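

Compound 1, compound 2 and compound 3 each give only a limit in this assay, so no step among them can be read: the limit of > 4000 nM in this assay, at which 3 of the 3 values shown sit.

The compounds shown leave open whether the changes among these three alter inhibition at all.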